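The source may hold more compounds than are shown below. What is called first, only, known or untested is meant among the compounds shown, and "the series" means these compounds.

For the measured compounds named here, in a functional assay on A549 cells (Homo sapiens) for cytotoxicity, read by MTT assay, with a stated time of 48 h (on this read-out lower numbers stand for stronger inhibition and higher numbers for weaker inhibition), compound 3 (`CC(C)n1c(/C=C2/C(=O)Nc3ccc(Cl)cc32)nc2ccccc21`) gives 35200 nM as the only actual number so far. Compound 1 (`CCn1c(/C=C2/C(=O)Nc3ccc(F)cc32)nc2ccccc21`) carries ethyl and reads > 50000 nM as a limit of the assay. Compound 2 (`CCn1c(/C=C2/C(=O)Nc3ccc(Br)cc32)nc2ccccc21`) also carries ethyl and reads > 50000 nM as a limit too. Compound 4 (`CCn1c(/C=C2/C(=O)Nc3ccc(Cl)cc32)nc2ccccc21`) departs from compound 3 by hydrogen in place of methyl on a saturated chain carbon bound to an aromatic nitrogen and a saturated chain carbon in the change isopropyl to ethyl. Going by the values given here, the only measured step, a step that the two limits leave unreadable from compound 1 to compound 2, gives no size to carry over, which leaves the limit of > 50000 nM in this assay, at which 2 of the 3 values shown sit, as the guide. The expected step in this assay is a 1.4-fold higher number from compound 3 to compound 4 (0.15 log units; within the scatter) toward weaker inhibition, probably within the scatter, and a reading at the limit is possible. For compound 4 the estimate is 50000 nM within an expected range of 28000 nM to 90000 nM for this read-out.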

Compound 4, half-maximal inhibitory concentration: > 50000 nM
Compound 4: only a limit was reported; the forecaster's own chance of this, stated with the estimate: 55%; the middle value lies on the limit itself.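

Hydrogen in place of methyl on this saturated chain carbon gives the first readable step in this assay (an at least 1.4-fold higher number from compound 3 to compound 4 (0.15 log units; that floor lies within the scatter)), and that step is only a floor within the scatter. Going by these compounds, compound 4 reads as a limit, so the true size of the change from isopropyl to ethyl stays unknown. The steps among compound 1, compound 2 and compound 4 cannot be read.

Open, on these data alone, is whether a longer chain such as butyl, or a chain carrying an amine, in place of isopropyl gives a lower number. Also open, as far as these compounds go, is how fluoro or bromo reads with isopropyl kept.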